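Aryl swap on the triazole nitrogen: outlook for compound 3

This account rests on a few compounds, and the source may have more. Where it says the series, first, only, none or still open, it means among the compounds named here.

For the measured compounds named here, compound 2 `CCc1ccccc1-n1nncc1CN1C(=O)C2(C(C#N)=C(N)Oc3c(N)cc4nc5ccccc5nc4c32)c2ccccc21` is the only member of the series with a numerical reading in an ADME assay on L02 cells (Homo sapiens) for antiproliferative activity, read by MTT assay, with a stated time of 48 h (a higher number here means a weaker inhibitor, a lower number a stronger inhibitor), where compound 2 gives 22900 nM. Compound 1 `Cc1ccccc1-n1nncc1CN1C(=O)C2(C(C#N)=C(N)Oc3c(N)cc4nc5ccccc5nc4c32)c2ccccc21` is its parent, and in this assay compound 1 reaches only the limit of the method, > 50000 nM. Going by the values given here, the one measured step, an at least 2.1-fold lower number from compound 1 to compound 2 (0.33 log units; beyond the scatter), cannot be sized exactly because of the limit of > 50000 nM in this assay, at which 1 of the 2 values shown sits.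

Compound 3 `N#CC1=C(N)Oc2c(N)cc3nc4ccccc4nc3c2C12C(=O)N(Cc1cnnn1-c1ccc(Cl)cc1)c1ccccc12` differs from compound 2 in one place: 4-chlorophenyl in place of 2-ethylphenyl on an aromatic nitrogen. Among the compounds with values here, no measured step covers this change directly, since the single step on record concerns methyl in place of hydrogen on a saturated chain carbon bound to an aromatic carbon, not the exchange of the whole aryl group. That step, an at least 2.1-fold lower number from compound 1 to compound 2 (0.33 log units; beyond the scatter), at least modest, shows that the substitution pattern of the aryl group can move the number in this assay, but its direction for compound 3 cannot be read from compound 1 and compound 2 alone. With the ethyl of compound 2 gone, a weaker reading is expected, a step of a 1.5-fold higher number from compound 2 to compound 3 (0.18 log units; within the scatter). For compound 3 the estimate in this assay is 35000 nM, between 12000 nM and 100000 nM, with a fair chance that only a limit is returned.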

Compound 3, half-maximal inhibitory concentration: > 50000 nM
Compound 3: only a limit was reported; the forecaster's own chance of this, stated with the estimate: 40%; at least 1.4-fold (0.15 log units) between middle value and limit.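

In this assay, the exchange at the aromatic nitrogen of the five-membered ring now covers the whole aryl group, not only the chain on it: 4-chlorophenyl in place of 2-ethylphenyl gives an at least 2.1-fold higher number from compound 2 to compound 3 (0.33 log units; beyond the scatter). Of the three aryl groups shown, 2-ethylphenyl is the only one that gives a numerical reading, while 2-methylphenyl in compound 1 and 4-chlorophenyl in compound 3 both end at a limit. The step between compound 1 and compound 3 cannot be read, and these two aryl groups cannot be ordered, because of the ceiling of the read-out: the limit of > 50000 nM in this assay, at which 2 of the 3 values shown sit.

The compounds shown leave open whether the lower number of compound 2 depends on the ethyl group itself or on where a substituent stands on the phenyl ring, as compound 3 changes both the group and its place. Also open, from the compounds shown here alone, is how a longer chain such as propyl, or an amine on the phenyl ring, would read in this assay, and whether any such group takes the number lower than that of compound 2.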